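Phenyl in place of bromo on the amide-side aryl

A few compounds are considered here, and "the series" means these few. Any claim that something is new, unique, unknown or untested is made for them only; others in the source may bear on it.

Three amides of the shared core have been measured in a functional assay on HCT-116 cells (Homo sapiens) for antiproliferative activity, read by MTT assay, with a stated time of 72 h; on this read-out higher numbers stand for weaker inhibition and lower numbers for stronger inhibition. Compound 1 `O=C(CCc1cccc2c1B(O)OC2)Nc1nccs1` gives > 100000 nM, which is a limit of the assay and not a number. Compound 2 `O=C(CCc1cccc2c1B(O)OC2)Nc1ccc(Br)cc1` gives 46000 nM and compound 3 `O=C(CCc1cccc2c1B(O)OC2)Nc1cccc(I)c1` gives 2300 nM. Among the two numbers, compound 2 stands highest: the step of a 20-fold lower number from compound 2 to compound 3 (1.30 log units; beyond the scatter) is large, and an at least 43-fold lower number from compound 1 to compound 3 (1.63 log units; beyond the scatter) and an at least 2.1-fold lower number from compound 1 to compound 2 (0.33 log units; beyond the scatter) are both beyond the scatter.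

The compound not yet measured is compound 4 `O=C(CCc1cccc2c1B(O)OC2)Nc1ccc(-c2ccccc2)cc1`, which differs from compound 2 by phenyl in place of bromo on an aromatic carbon. Among the measured compounds shown here, no measured step exchanges bromo for phenyl, so none bears on it directly. What the measured steps do show is that the aryl group on the amide nitrogen governs the read-out: a 20-fold lower number from compound 2 to compound 3 (1.30 log units; beyond the scatter) is large for a change of halogen and of its position. A change on the same ring in compound 4 is therefore expected to move the number beyond the scatter, though its direction is not fixed by the data; a moderately lower number is taken as the expectation, a 3.1-fold lower number from compound 2 to compound 4 (0.49 log units; beyond the scatter). For compound 4 the estimate is 15000 nM, with a range from 3000 nM to 70000 nM.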

Compound 4, half-maximal inhibitory concentration: 13000 nM
For compound 4 the middle estimate is 1.2-fold (0.06 log units) above the measured one, and the stated range covers the measured number.
By their numbers in this assay, from the lowest: compound 3; then compound 4; then compound 2. At a limit, above all of these: compound 1.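

The exchange of bromo for phenyl is the first change shown that keeps the ring on the amide nitrogen and alters only what it carries, and in this assay it gives a 3.5-fold lower number from compound 2 to compound 4 (0.55 log units; beyond the scatter). At this aromatic carbon, para to a large group, 6 heavy atoms and a six-membered aromatic ring of carbon only can thus replace the 1 heavy atom of bromo with no rise in the number, and the step is modest beside the large 20-fold lower number from compound 2 to compound 3 (1.30 log units; beyond the scatter). No measurement shown accounts for the direction or the size of this step.

As far as these compounds go, it remains open whether a smaller or a differently built group at the same carbon, such as an amine, a carboxylic acid or a methoxy group, would lower the number further or raise it, and whether a phenyl ring bearing its own substituent would go beyond compound 4. Also open, from the compounds shown here alone, is whether phenyl in place of iodo on compound 3 would behave as it does here, and whether a longer chain between the carbonyl and the shared core would change the picture.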